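A few compounds are considered here, and "the series" means these few. Any claim that something is new, unique, unknown or untested is made for them only; others in the source may bear on it.

Measured compounds in a functional assay on Shh Light II cells (Mus musculus) for inhibition, read by a luciferase reporter; a higher number here means a weaker inhibitor, a lower number a stronger inhibitor:
Compound 1 `N#Cc1ccccc1NC(=O)N1CCC(c2nc(-c3ccc4ccccc4n3)no2)CC1` gives 190 nM.
Compound 2 `O=C(NCC1CCC1)N1CCC(c2nc(-c3ccc4ccccc4n3)no2)CC1` gives 410 nM.
Compound 3 `O=C(Nc1cccc2cccnc12)N1CCC(c2nc(-c3ccc4ccccc4n3)no2)CC1` gives 1400 nM.

Compound 3 stands highest of the three, so it is the weakest inhibitor here: a 7.4-fold higher number from compound 1 to compound 3 (0.87 log units; beyond the scatter) and a 3.4-fold higher number from compound 2 to compound 3 (0.53 log units; beyond the scatter) are both beyond the scatter. Compound 4 `O=C(OCc1ccccc1)N1CCC(c2nc(-c3ccc4ccccc4n3)no2)CC1` is not yet measured. Its change from compound 3 is benzyloxy in place of (quinolin-8-yl)amino on a carbonyl carbon. The measured steps each swap a group on an amide-type nitrogen, not the whole (quinolin-8-yl)amino, so none shows this exact change. Still, compound 4 is expected to give a lower number than compound 3 because a 7.4-fold higher number from compound 1 to compound 3 (0.87 log units; beyond the scatter) and a 3.4-fold higher number from compound 2 to compound 3 (0.53 log units; beyond the scatter) ran upward toward quinolin-8-yl, giving an expected step of a 2.8-fold lower number from compound 3 to compound 4 (0.45 log units; beyond the scatter) in this assay. The estimate for compound 4 is 500 nM, ranging from 150 nM to 2000 nM.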

Compound 4, half-maximal inhibitory concentration: > 2500 nM
Compound 4 gave a limit, no number (the forecaster's own chance of this, stated with the estimate: 5%); middle value at least 5.0-fold (0.69 log units) away from the limit.
By their numbers in this assay, from the lowest: compound 1; then compound 2; then compound 3. At a limit, above all of these: compound 4.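

In this assay compound 4 gives > 2500 nM, which is a limit of the assay and not a number. The earlier compounds shown here varied only the group on the nitrogen, whereas benzyloxy, with 0 hydrogen-bond donors, puts an oxygen on the carbonyl carbon and brings no gain: there is an at least 13-fold higher number from compound 1 to compound 4 (1.11 log units; beyond the scatter) and an at least 6.0-fold higher number from compound 2 to compound 4 (0.78 log units; beyond the scatter). Against the weakest earlier compound, the order stays unsettled, with an at least 1.7-fold higher number from compound 3 to compound 4 (0.25 log units; that floor lies within the scatter).

From the compounds shown here alone, it remains open whether the oxygen or the benzyl part drives this loss, a question that benzylamino on the same carbonyl carbon would separate. How far compound 4 lies beyond its limit is also unknown.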